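The source may hold more compounds than are shown below. What is called first, only, known or untested is meant among the compounds shown, and "the series" means these compounds.

Measured so far:
- compound 1 `COC1=C(OC)[C@H](O)[C@H](C/C=C(\C)CC/C=C(\C)C[C@H](O)/C=C(\C)CO)[C@@H](C)C1=O`: in a functional assay on PC-3 cells (Homo sapiens) for inhibition, read by sulforhodamine B assay, with a stated time of 48 h (on this read-out higher numbers stand for weaker inhibition of growth and lower numbers for stronger inhibition of growth), compound 1 gives > 30000 nM, a limit of the assay and not a number.
- compound 2 `COC1=C(OC)[C@H](O)[C@H](C/C=C(\C)CC/C=C(\C)CCC=C(C)C)[C@@H](C)C1=O`: in this assay compound 2 gives 13500 nM.

Within the data shown here, compound 2 thus holds the only actual number in this assay; the one other value is a limit. Among the measured compounds shown here, the single measured step is an at least 2.2-fold lower number from compound 1 to compound 2 (0.34 log units; beyond the scatter); its true size is bounded only by the limit of > 30000 nM in this assay, at which 1 of the 2 values shown sits. In that step the side chain lost both oxygens and the number fell.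

Compound 3 `COC1=C(OC)[C@H](O)[C@H](C/C=C(\C)CC/C=C(\C)C/C=C/C(C)(C)O)[C@@H](C)C1=O` is not yet measured. It differs from compound 2 by 3-hydroxy-3-methylbut-1-en-1-yl in place of 3-methylbut-2-en-1-yl on a saturated chain carbon bound to a double-bonded chain carbon. For the measured compounds named here, the only step that bears on this is the one from compound 1 to compound 2, and it ran toward the lower number when oxygen was taken out of the chain. The change to compound 3 puts one hydroxyl back, at a different spot, so a modest move toward the higher number is expected rather than none, with a real chance of landing at the limit again. Expected, then, is a 1.6-fold higher number from compound 2 to compound 3 (0.21 log units; within the scatter). For compound 3 the estimate is 22000 nM, in the range 9000 nM to 50000 nM.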

Compound 3, concentration for 50% growth inhibition: > 30000 nM
Compound 3: only a limit was reported; the forecaster's own chance of this, stated with the estimate: 30%; middle value at least 1.3-fold (0.13 log units) from the limit.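

In this assay compound 3 gives > 30000 nM, a limit of the assay and not a number. Placing 3-hydroxy-3-methylbut-1-en-1-yl in place of 3-methylbut-2-en-1-yl on a saturated chain carbon bound to a double-bonded chain carbon gives an at least 2.2-fold higher number from compound 2 to compound 3 (0.34 log units; beyond the scatter); this one change already returns the series to the limit, without the rest of the side chain of compound 1. The step between compound 1 and compound 3 cannot be read, and the full size of the step to compound 3 also stays unknown: the limit of > 30000 nM in this assay, at which 2 of the 3 values shown sit.

The entering group differs from the leaving one both by its hydroxyl and by where its double bond lies, and the compounds shown do not separate these two changes. Also open, going by these compounds, is whether another group at this place, such as an amine, a carboxylic acid or a longer chain, would keep a measurable number in this assay or improve on compound 2.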